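Fluoro for hydroxy on compound 3: working notes

The source may hold more compounds than are shown below. What is called first, only, known or untested is meant among the compounds shown, and "the series" means these compounds.

compound 1 `COc1ccc(C=C(C(=O)c2cc(OC)c(OC)c(OC)c2)c2ccccc2O)cc1O`: 35000 nM
compound 2 `COc1ccc(/C=C(/C(=O)c2cc(OC)c(OC)c(OC)c2)c2ccccc2O)cc1F`: 60000 nM
compound 3 `COc1ccc(C(=Cc2ccc(OC)c(O)c2)C(=O)c2cc(OC)c(OC)c(OC)c2)cc1`: 12000 nM

All three values come from a functional assay on K562 cells (Homo sapiens) for antiproliferative activity, read by MTT assay, with a stated time of 5 days; a higher number here means a weaker inhibitor, a lower number a stronger inhibitor. Among the compounds with values here, compound 3 has the lowest number of the three, and a 2.9-fold lower number from compound 1 to compound 3 (0.46 log units; beyond the scatter) is the only measured step. Next in line is compound 4 `COc1ccc(C(=Cc2ccc(OC)c(F)c2)C(=O)c2cc(OC)c(OC)c(OC)c2)cc1`, where 3-hydroxy-4-methoxyphenyl becomes 3-fluoro-4-methoxyphenyl: fluoro in place of hydroxy on an aromatic carbon. That step from compound 1 concerns 4-methoxyphenyl in place of 2-hydroxyphenyl, a different part of the molecule, so it sets the background but not the size of the step here. The nearest guide is a pair of values: compound 1 at 35000 nM and compound 2 at 60000 nM lie within the usual scatter of each other. On that evidence, no step beyond the scatter is expected in this assay. The expected step is a 1.3-fold higher number from compound 3 to compound 4 (0.12 log units; within the scatter). For compound 4 the estimated value is 16000 nM, with an expected range of 6000 nM to 40000 nM.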

Compound 4, half-maximal inhibitory concentration: 450000 nM
Beside the measured number, compound 4's estimate is 28-fold (1.45 log units) below it, outside the stated range (above it).
By their numbers in this assay, from the lowest: compound 3; then compounds 1 and 2 (each within the scatter of the next); then compound 4.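

In this assay this aromatic carbon, ortho to a methoxy group, proves highly sensitive in the compound 3 setting: fluoro in place of hydroxy gives a 38-fold higher number from compound 3 to compound 4 (1.57 log units; beyond the scatter) and is the largest step in the series. The same exchange between the two compounds carrying 2-hydroxyphenyl is far smaller, with compound 1 at 35000 nM and compound 2 at 60000 nM, values within the scatter of each other, so across these two pairs the effect of the exchange differs with the group on the double-bonded chain carbon. Nothing available here accounts for the size of the step or for this difference between the pairs.

The compounds shown leave open whether an amine or a carboxylic acid on this aromatic carbon would stay near the number of compound 3 or move towards that of compound 4. They also leave open how an ethoxy group in place of the neighbouring methoxy group would alter the value of compound 3.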